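Methoxy to ethoxy on the pyrimidine of compound 2

A few compounds are considered here, and "the series" means these few. Any claim that something is new, unique, unknown or untested is made for them only; others in the source may bear on it.

Measured compounds:
Compound 1, `COc1ccc(-c2nc(C(F)(F)F)sc2N2CCN(C(=O)Cn3cnc4cccnc43)[C@H](C)C2)cc1`: 13 nM
Compound 2, `COc1ncc(-c2nc(C(F)(F)F)sc2N2CCN(C(=O)Cn3cnc4cccnc43)[C@H](C)C2)cn1`: 3.8 nM

In a functional assay on CHO-K1 cells for antagonist activity at C-X-C chemokine receptor type 3 (Homo sapiens), read by FLIPR, with a stated time of 10 min (on this read-out lower numbers stand for stronger inhibition and higher numbers for weaker inhibition), compound 1 gives 13 nM, and compound 2 gives 3.8 nM. Within the data shown here, the one measured step, a 3.4-fold lower number from compound 1 to compound 2 (0.53 log units; beyond the scatter), is the change from 4-methoxyphenyl to 2-methoxypyrimidin-5-yl on an aromatic carbon. Compound 2 therefore stands at the lowest number of the two.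

Compound 3, `CCOc1ncc(-c2nc(C(F)(F)F)sc2N2CCN(C(=O)Cn3cnc4cccnc43)[C@H](C)C2)cn1`, is yet to be measured. It differs from compound 2 by methyl in place of hydrogen on a saturated chain carbon bound to an oxygen on an aromatic ring: methyl to ethyl, methoxy to ethoxy, 2-methoxypyrimidin-5-yl to 2-ethoxypyrimidin-5-yl. Among the measured compounds shown here, no measured step touches this part of the molecule; the only step available, from compound 1 to compound 2, exchanges the aromatic ring itself and says nothing about lengthening the alkoxy chain. The expectation is thus a step of no size beyond the scatter in this assay, in either direction, written as a 1.2-fold higher number from compound 2 to compound 3 (0.07 log units; within the scatter). For compound 3 the estimated value is 4.5 nM, with a range from 1.5 nM to 14 nM.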

Compound 3, half-maximal inhibitory concentration: 2 nM
Compound 3: middle estimate off by 2.3-fold (0.35 log units), on the high side; the range from low to high includes it.
By their numbers in this assay, from the lowest: compounds 3 and 2 (each within the scatter of the next); then compound 1.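

In this assay, methyl in place of hydrogen on the saturated chain carbon bound to an oxygen on an aromatic ring gives a 1.9-fold lower number from compound 2 to compound 3 (0.28 log units; within the scatter), and this step lies within the scatter, so the assay does not separate the ethoxy group of compound 3 from the methoxy group of compound 2. Among these compounds, this is the first measured change at this position, and it shows that the position accepts the methoxy to ethoxy change with no step beyond the scatter, while the full exchange of 4-methoxyphenyl for 2-ethoxypyrimidin-5-yl gives a 6.5-fold lower number from compound 1 to compound 3 (0.81 log units; beyond the scatter), which lies beyond the scatter. Nothing in the available evidence explains why the ethoxy group is accepted here.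

Going by these compounds, with only methoxy and ethoxy at this position, it remains open whether the tolerance extends to a longer chain such as propoxy, a branched isopropoxy group, or a dimethylamino group in place of the alkoxy oxygen. On these data alone, it is also open whether 4-ethoxyphenyl would track the pyrimidine pair, since the ethoxy change is seen on the pyrimidine alone.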